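A urea to an amide at the edge of the shared core

A few compounds are considered here, and "the series" means these few. Any claim that something is new, unique, unknown or untested is made for them only; others in the source may bear on it.

Three compounds built on one core have been examined in a functional assay on SK-MEL-28 cells (Homo sapiens) for inhibition, read by sulforhodamine B assay, with a stated time of 48 h, tested at 0.01 uM; on this read-out higher numbers stand for a weaker effect at the one concentration tested and lower numbers for a stronger effect. Compound 1 `O=C(Nc1cccc(-n2cc(-c3ccncc3)c(-c3cc(O)cc(Cl)c3)n2)c1)Nc1ccc(Cl)c(C(F)(F)F)c1` gives 97%, compound 2 `COc1cc(Cl)cc(-c2nn(-c3cccc(NC(=O)Nc4ccc(Cl)c(C(F)(F)F)c4)c3)cc2-c2ccncc2)c1` gives 98%, and compound 3 `COc1cc(Cl)cc(-c2nn(-c3cccc(NC(=O)Nc4cc(C(F)(F)F)cc(C(F)(F)F)c4)c3)cc2-c2ccncc2)c1` gives 103%. For the measured compounds named here, the single step measured in one place, methyl in place of hydrogen on an oxygen on an aromatic ring, is a number 1 percentage points higher from compound 1 to compound 2 (within the scatter). Compound 2 therefore stands among the three values without separating from either neighbour: compound 1 lies nearest, compound 3 furthest, and both gaps sit inside the usual scatter, so nothing distinguishes the three at this concentration.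

Compound 4 `COc1cc(Cl)cc(-c2nn(-c3cccc(NC(=O)c4cccc(C(F)(F)F)c4)c3)cc2-c2ccncc2)c1` has not yet been measured in this assay. It differs from compound 2 in one place: 3-(trifluoromethyl)phenyl in place of (4-chloro-3-(trifluoromethyl)phenyl)amino on a carbonyl carbon. Going by the values given here, no measured step touches this part of the molecule; the only step in hand concerns the oxygen substituent and was itself within the scatter. With every measured compound showing a weak effect at the one concentration tested, compound 4 is expected to behave alike, with a step of no change at the digits printed from compound 2 to compound 4 (within the scatter) that stays inside the scatter. The estimate for compound 4 is 98%, within a range from 88% to 106%.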

Compound 4, a percentage reported as activity, at one concentration (the size of the read-out at that concentration, not a potency): 105%
For compound 4 the middle estimate is 7 percentage points below the measured one; the measured number falls inside the stated range.
By their numbers in this assay, from the lowest: compounds 1, 2, 3 and 4 (each within the scatter of the next).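

In this assay, the exchange of (4-chloro-3-(trifluoromethyl)phenyl)amino for 3-(trifluoromethyl)phenyl on the carbonyl carbon, which turns the urea into an amide, gives a number 7 percentage points higher from compound 2 to compound 4 (within the scatter). For the compounds shown here, this is the first measured step at this position, and it shows that the read-out at this one concentration does not separate the amide from the urea, even though the change removes the nitrogen with its hydrogen-bond donor and the chlorine together. No supporting measurement is available to explain this result.

The step changes the linking nitrogen and the chlorine at once, so the compounds shown cannot tell what either change would do alone, and a single concentration at which all four compounds read alike cannot show whether a difference would appear under conditions where the effect is stronger. Also open, going by these compounds, is how the read-out would respond to a carboxylic acid, a morpholine or a longer chain in place of the 3-(trifluoromethyl)phenyl on the carbonyl carbon.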